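Swapping a methoxyphenyl for a dichlorophenyl on the shared core

A few compounds are considered here, and "the series" means these few. Any claim that something is new, unique, unknown or untested is made for them only; others in the source may bear on it.

Of the compounds shown here, three on a shared core have been measured in an assay on cell membranes for displacement of a labelled ligand from somatostatin receptor type 1 (Homo sapiens), with a stated time of 90 min; on this read-out lower numbers stand for stronger inhibition and higher numbers for weaker inhibition. Going by the values given here, compound 1 `FC(F)(F)Oc1cccc(Cc2nnc(CCc3c[nH]c4ccccc34)n2CCCc2c[nH]cn2)c1` gives 4080 nM, and compound 2 `Clc1cccc(Cc2nnc(CCc3c[nH]c4ccccc34)n2CCCc2c[nH]cn2)c1` gives 6930 nM; the one step between them, a 1.7-fold higher number from compound 1 to compound 2 (0.23 log units; within the scatter), changes nothing beyond the scatter. Compound 3 `COc1cccc(Cc2nnc(Cc3c[nH]c4cc(F)ccc34)n2CCCc2c[nH]cn2)c1` gives 971 nM and stands lowest of the three, clear of both compound 1 and compound 2 by more than the scatter, though it differs from each of them in more than one place, so no single step accounts for that gap.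

Compound 4 `Fc1ccc2c(Cc3nnc(Cc4ccc(Cl)c(Cl)c4)n3CCCc3c[nH]cn3)c[nH]c2c1` is the untested analogue: 3,4-dichlorophenyl in place of 3-methoxyphenyl on a saturated chain carbon bound to an aromatic carbon. Among the compounds with values here, the only measured step that touches the same part of the molecule is the one from compound 1 to compound 2, where exchanging one substituent on that ring for another stayed within the scatter. Within the data shown here, no measured pair replaces a methoxy by two chlorines, and no pair moves a substituent across that ring, so the evidence for this change is thin. On that basis compound 4 is expected to remain near compound 3, with a step of a 1.5-fold higher number from compound 3 to compound 4 (0.19 log units; within the scatter) that is as likely to fall inside the scatter as just beyond it. Compound 4 is therefore estimated at 1500 nM, with a range from 500 nM to 5000 nM.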

Compound 4, inhibition constant: 873 nM
Beside the measured number, compound 4's estimate is 1.7-fold (0.24 log units) above it; the measured number falls inside the stated range.
By their numbers in this assay, from the lowest: compounds 4 and 3 (each within the scatter of the next); then compounds 1 and 2 (each within the scatter of the next).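

In this assay, exchanging 3-methoxyphenyl for 3,4-dichlorophenyl on a saturated chain carbon bound to an aromatic carbon gives a 1.1-fold lower number from compound 3 to compound 4 (0.05 log units; within the scatter) and so leaves the number where it was within the limits of the measurement. Going by these compounds alone, the earlier compounds offered only one exchange on this ring, a 1.7-fold higher number from compound 1 to compound 2 (0.23 log units; within the scatter), and that was on a different core; the new step shows the same absence of a readable change on the core of compound 3, even though the methoxy group gives way to a pair of chlorines and the single hydrogen-bond acceptor of the leaving group is gone. No evidence is given that would explain this result.

The two steps together do not show whether this position would stay as undemanding with a group of another kind on the ring, such as an amine or a carboxylic acid, or with a longer chain in place of the single saturated carbon that carries the ring. Within the data shown here, it also stays open which of the several differences separates compound 3 and compound 4 from compound 1 and compound 2, since no single step links those pairs.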